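Chloro ortho to methoxy: an untested step from compound 3

A few compounds are considered here, and "the series" means these few. Any claim that something is new, unique, unknown or untested is made for them only; others in the source may bear on it.

Three compounds have been measured in a functional assay on MCF7 cells (Homo sapiens) for cytotoxicity, read by sulforhodamine B assay, with a stated time of 72 h; a higher number here means a weaker inhibitor, a lower number a stronger inhibitor:

compound 1, `CCS(=O)(=O)Nc1cc(-c2ccc3ncnc(Nc4ccc(F)cc4)c3c2)cnc1OC`: 6510 nM
compound 2, `CCS(=O)(=O)Nc1cc(-c2ccc3ncnc(Nc4ccc(OC(F)(F)F)cc4)c3c2)cnc1OC`: 23700 nM
compound 3, `CCS(=O)(=O)Nc1cc(-c2ccc3ncnc(Nc4ccc(OC)cc4)c3c2)cnc1OC`: 1790 nM

Compound 3 gives the lowest of the three numbers. Its nearest neighbour is compound 1, and the step of a 3.6-fold lower number from compound 1 to compound 3 (0.56 log units; beyond the scatter) lies beyond the scatter. Compound 2 is furthest away: the step of a 13-fold lower number from compound 2 to compound 3 (1.12 log units; beyond the scatter) is large. The remaining pair, a 3.6-fold higher number from compound 1 to compound 2 (0.56 log units; beyond the scatter), is modest but also beyond the scatter. All three steps exchange one group on the same aromatic carbon of the anilino ring, the carbon that carries the methoxy in compound 3.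

Compound 4, `CCS(=O)(=O)Nc1cc(-c2ccc3ncnc(Nc4ccc(OC)c(Cl)c4)c3c2)cnc1OC`, keeps that methoxy and differs from compound 3 by chloro in place of hydrogen on an aromatic carbon. Going by the values given here, no measured step adds anything at the position where the chloro enters, so none of them bears directly on this change; the three steps only show that the anilino ring is sensitive to what sits on it. With the methoxy retained, the expected step is a 1.2-fold lower number from compound 3 to compound 4 (0.08 log units; within the scatter), not beyond the scatter in either direction. Compound 4 is therefore estimated at 1500 nM, within a range of 500 nM to 5000 nM in this assay.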

Compound 4, half-maximal inhibitory concentration: 3320 nM
For compound 4 the middle estimate is 2.2-fold (0.35 log units) below the measured one; the range from low to high includes it.
By their numbers in this assay, from the lowest: compounds 3, 4 and 1 (each within the scatter of the next, the first and the last beyond it); then compound 2.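

In this assay, chloro in place of hydrogen on an aromatic carbon, ortho to a methoxy group, gives a step that cannot be told from the scatter (a 1.9-fold higher number from compound 3 to compound 4 (0.27 log units; within the scatter)), so this position accepts the chloro with the methoxy retained and shows no change beyond the scatter. The 3-chloro-4-methoxyphenyl group of compound 4 also stands well clear of the 4-(trifluoromethoxy)phenyl group of compound 2 (a 7.1-fold lower number from compound 2 to compound 4 (0.85 log units; beyond the scatter)), yet cannot be separated from the 4-fluorophenyl group of compound 1 (a 2.0-fold lower number from compound 1 to compound 4 (0.29 log units; within the scatter)), so compound 4 sits within the scatter of both compound 3 and compound 1, although those two lie beyond the scatter of each other. No independent evidence bears on this result, and what lies behind it stays unexplained.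

The chloro is seen here only alongside the methoxy, so the compounds shown leave open whether it would give a similar result with fluoro or trifluoromethoxy in the methoxy's place. They also leave open how a bromo, a nitrile, an amine or a longer chain would fare on the carbon that carries the chloro.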